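A few compounds are considered here, and "the series" means these few. Any claim that something is new, unique, unknown or untested is made for them only; others in the source may bear on it.

In a functional assay on MDA-MB-231 cells (Homo sapiens) for inhibition, read by MTT assay (on this read-out higher numbers stand for weaker inhibition of growth and lower numbers for stronger inhibition of growth), compound 1 (`CC1=C(/C=C/C(C)=C/C=C/C(C)=C\C(=O)Nc2ccc(O)cc2)C(C)(C)CCC1n1ccnc1`) gives 13100 nM and compound 2 (`CC1=C(/C=C/C(C)=C/C=C/C(C)=C\C(=O)Nc2ccccc2O)C(C)(C)CCC1n1ccnc1`) gives 4670 nM, the lower of the two numbers. Compound 3 (`CC1=C(/C=C/C(C)=C/C=C/C(C)=C\C(=O)NCc2ccc(F)cc2)C(C)(C)CCC1n1ccnc1`) places 4-fluorobenzyl in place of 2-hydroxyphenyl on the amide-type nitrogen: 4-fluorobenzyl in place of 2-hydroxyphenyl on an amide-type nitrogen. For the measured compounds named here, the only measured step, a 2.8-fold lower number from compound 1 to compound 2 (0.45 log units; beyond the scatter), is modest and beyond the scatter, but it compares only two hydroxyphenyl groups, so it bears loosely on this change. No benzyl amide has been measured yet. The expected change is of similar modest size, towards a higher number: an estimated 1.6-fold higher number from compound 2 to compound 3 (0.21 log units; within the scatter). For compound 3 the expected value is 7500 nM, with an estimated range of 2500 nM to 20000 nM.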

Compound 3, concentration for 50% growth inhibition: 1410 nM
For compound 3 the middle estimate is 5.3-fold (0.73 log units) above the measured one; the measured number lies below the stated range.
By their numbers in this assay, from the lowest: compound 3; then compound 2; then compound 1.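

In this assay the change to 4-fluorobenzyl on the amide-type nitrogen gives a 3.3-fold lower number from compound 2 to compound 3 (0.52 log units; beyond the scatter) and also a 9.3-fold lower number from compound 1 to compound 3 (0.97 log units; beyond the scatter) in the comparison with the other hydroxyphenyl amide. A hydroxyphenyl group is therefore not needed at this position for the lowest number in the series, and the entering group counts no hydrogen-bond donor or acceptor. Nothing available explains this shift.

The compounds shown do not separate the contribution of the fluorine from that of the benzyl link. Plain benzyl, 4-hydroxybenzyl or a longer 2-phenylethyl chain on the same nitrogen would bear on that.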